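The compounds below may be only part of what the source reports. "The series", "measured", "known", "first", "only" and "open" are said of these compounds alone.

Measured in a functional assay on HCT-116 cells (Homo sapiens) for cytotoxicity, read by MTT assay, with a stated time of 72 h; a higher number here means a weaker inhibitor, a lower number a stronger inhibitor:
- Compound 1 `O=C(NCc1ccc(F)cc1)c1nc(Br)c2cccnc2c1NCCO`: > 20000 nM
- Compound 2 `NCCNc1c(C(=O)NCc2ccc(F)cc2)nc(Br)c2cccnc12`: > 20000 nM

Neither entry is a true number. For compound 1, > 20000 nM is a limit of the assay. For compound 2, > 20000 nM is likewise a limit, so it has no exact place on the scale. The evidence so far is the limit of > 20000 nM in this assay, at which 2 of the 2 values shown sit.

Compound 3 `CNCCCNc1c(C(=O)NCc2ccc(F)cc2)nc(Br)c2cccnc12` has not yet been measured. It differs from compound 2 in one place: (methylamino)methyl in place of amino on a saturated chain carbon, two bonds along the chain from a nitrogen on an aromatic ring. Put simply, a 2-aminoethyl chain becomes a 3-(methylamino)propyl chain, so (methylamino)methyl stands in place of amino.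

Going by the values given here, only one measured step bears on this change, and it concerns the same place on the chain: a step that the two limits leave unreadable from compound 1 to compound 2. That step has no readable size or direction to carry over, so no shift beyond the scatter can be predicted in this assay. Compound 3 is therefore expected to remain in the same region, and it may well be reported only as a limit.

The expected change is a number no higher from compound 2 to compound 3 (the limit leaves the size open).

For compound 3, the estimate is 20000 nM, with an expected range of 6000 nM to 40000 nM.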

Compound 3, half-maximal inhibitory concentration: 9000 nM
Beside the measured number, compound 3's estimate is 2.2-fold (0.35 log units) above it; measured number inside the range.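

In this assay, going by these compounds alone, compound 3 gives 9000 nM, the first true number in this small series. This shows that the read-out can respond to a change at this place on the chain, which the earlier step could not show, as it lay between two limits and cannot be read. Putting (methylamino)methyl in place of amino gives an at least 2.2-fold lower number from compound 2 to compound 3 (0.34 log units; beyond the scatter), and putting it in place of hydroxy gives an at least 2.2-fold lower number from compound 1 to compound 3 (0.34 log units; beyond the scatter); both steps lie beyond the scatter, but their full size stays open, since the other compounds remain at a limit: the limit of > 20000 nM in this assay, at which 2 of the 3 values shown sit.

The change from a 2-aminoethyl chain to a 3-(methylamino)propyl chain both lengthens the chain and adds a methyl group on its terminal nitrogen, so the compounds shown cannot say which of the two goes with the lower number. A 3-aminopropyl chain and a 2-(methylamino)ethyl chain would each separate these two changes, while a longer 4-(methylamino)butyl chain or a terminal dimethylamino group would test how far the trend at this place extends.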